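Removing the nitro group from compound 1

This account rests on a few compounds, and the source may have more. Where it says the series, first, only, none or still open, it means among the compounds named here.

Compound 1 `O=C1OCC[C@@H]1NC(=S)SCCOc1ccc([N+](=O)[O-])cc1` gives in a functional assay on MCF7 cells (Homo sapiens) for antiproliferative activity, read by MTT assay, with a stated time of 72 h (on this read-out higher numbers stand for weaker inhibition and lower numbers for stronger inhibition), only a limit: > 64000 nM. Compound 2 `O=C1OCC[C@@H]1NC(=S)SCCOc1cccc2ccccc12` likewise reaches only a limit, > 64000 nM, in this assay. Compound 1 therefore stands at the limit of > 64000 nM in this assay, at which 2 of the 2 values shown sit, with no measured number separating it from compound 2. Compound 3 `O=C1OCC[C@@H]1NC(=S)SCCOc1ccccc1` differs from compound 1 by hydrogen in place of nitro on an aromatic carbon. No measured step sizes this change; in this assay no shift beyond the scatter is expected, and a limit again seems the likely outcome. The expected step is a step that the limit leaves unreadable from compound 1 to compound 3. Compound 3 is expected at 100000 nM, within 30000 nM to 400000 nM.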

Compound 3, half-maximal inhibitory concentration: > 64000 nM
Compound 3: only a limit was reported; the forecaster's own chance of this, stated with the estimate: 85%; the middle value lies beyond the limit too.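

No step can be read from compound 1 to compound 3 in this assay, as both compounds give only a limit: the limit of > 64000 nM in this assay, at which 3 of the 3 values shown sit.

The compounds shown leave open whether any change to the shared core gives a measured number rather than a limit in this assay.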